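Swapping cyclohexyl for benzyl on a bis-benzimidazole scaffold

The source may report more compounds than this note shows. Statements on the series, on what has been measured and on what is new or still open speak of the compounds shown alone.

Measured compounds:
compound 1 `Clc1ccc(-c2cn3ccnc3c(-c3ccc4ncn(C5CCCCC5)c4c3)n2)cc1` gives 5.44%
compound 2 `c1cn2cc(-c3ccc4c(c3)ncn4C3CCCCC3)nc(-c3ccc4ncn(C5CCCCC5)c4c3)c2n1` gives 14.9%

Both were tested in a functional assay on UACC-257 cells (Homo sapiens) for inhibition, read by sulforhodamine B assay, with a stated time of 48 h, tested at 10 uM; a higher number here means more inhibition at the concentration tested (going by the name of the read-out), a lower number less inhibition. Compound 1 carries a single cyclohexyl-bearing unit, whereas compound 2 carries two of them, one on each side of the shared core. Of the two numbers, compound 2 has the higher one, but the gap to compound 1 lies within the usual scatter of this kind of measurement, so the two cannot be told apart with confidence. Both numbers are modest for this assay.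

Compound 3 `c1ccc(Cn2cnc3ccc(-c4nc(-c5ccc6c(c5)ncn6C5CCCCC5)cn5ccnc45)cc32)cc1` is not yet measured. It keeps the core of compound 2 and changes one thing: benzyl in place of cyclohexyl on an aromatic nitrogen. Within the data shown here, no measured pair shows this exact change, so nothing directly tells how the assay responds to it. Among the measured compounds shown here, with only two close numbers in hand, the expected step of a number 2.9 percentage points lower from compound 2 to compound 3 (within the scatter) is none beyond the scatter, in either direction. Compound 3 is therefore expected to give about 12%, in a range from 0% to 30%.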

Compound 3, a percentage reported as inhibition, at one concentration (the size of the read-out at that concentration, not a potency): -32.7%
Beside the measured number, compound 3's estimate is 44.7 percentage points above it; the measured number lies below the stated range.
By their numbers in this assay, from the lowest: compound 3; then compounds 1 and 2 (each within the scatter of the next).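

Putting benzyl in place of cyclohexyl on an aromatic nitrogen gives a number 47.6 percentage points lower from compound 2 to compound 3 (beyond the scatter) in this assay, so this position clearly matters, something the two earlier compounds, whose numbers lay within the scatter of each other, could not show. The change looks modest on paper, since one six-membered carbon ring, non-aromatic in cyclohexyl, gives way to an aromatic one in benzyl, and neither group has hydrogen-bond donors or acceptors, yet compound 3 gives -32.7%, a negative inhibition figure unlike the positive numbers of the other two. Nothing available explains why this swap has so large an effect.

What the compounds shown leave open is whether the drop belongs to benzyl itself or would also appear with other groups on that nitrogen, such as a small methyl, a longer phenylethyl chain or a chain ending in an amine. Going by these compounds, it is also open whether changing the remaining cyclohexyl on the other side of the shared core to benzyl would give a step of similar size.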